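Amide cap variation on the shared core

The compounds below may be only part of what the source reports. "The series", "measured", "known", "first", "only" and "open" are said of these compounds alone.

Compound 2 `CCCCCCCCC(=O)N1c2ccccc2CCC1C(=O)Nc1ccccc1O` carries an octyl group on the carbonyl carbon attached to the ring nitrogen; in a functional assay on NCI-H23 cells (Homo sapiens) for cytotoxicity, read by sulforhodamine B assay, with a stated time of 72 h (on this read-out lower numbers stand for stronger inhibition of growth and higher numbers for weaker inhibition of growth), compound 2 gives 55800 nM, the larger of the two numbers to date, though its gap to compound 1 is within the scatter. Compound 1 `O=C(Nc1ccccc1O)C1CCc2ccccc2N1C(=O)c1ccccc1Cl` has 2-chlorophenyl in that place, and compound 1 gives 46900 nM in this assay; the step of a 1.2-fold higher number from compound 1 to compound 2 (0.08 log units; within the scatter) is within the scatter. Compound 3 `O=C(Nc1ccccc1O)C1CCc2ccccc2N1C(=O)c1cccc(Cl)c1` is the next member: 3-chlorophenyl in place of octyl on a carbonyl carbon. Going by the values given here, the only measured step that bears on this change is the exchange of an aryl cap for the octyl chain from compound 1 to compound 2, which was within the scatter; no measured pair compares 3-chlorophenyl with 2-chlorophenyl. The step of a 1.2-fold lower number from compound 2 to compound 3 (0.09 log units; within the scatter) is therefore expected to stay within the scatter, with no clear direction. Compound 3 is estimated to give 45000 nM in this assay, with a range of 20000 nM to 100000 nM.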

Compound 3, concentration for 50% growth inhibition: 11600 nM
Compound 3: middle estimate off by 3.9-fold (0.59 log units), on the high side; the whole stated range lies above it.
By their numbers in this assay, from the lowest: compound 3; then compounds 1 and 2 (each within the scatter of the next).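

The cap on the carbonyl carbon is not indifferent in this assay: 3-chlorophenyl in place of octyl gives a 4.8-fold lower number from compound 2 to compound 3 (0.68 log units; beyond the scatter), a step beyond the scatter, unlike the earlier exchange between octyl and 2-chlorophenyl. 3-Chlorophenyl in place of 2-chlorophenyl gives a 4.0-fold lower number from compound 1 to compound 3 (0.61 log units; beyond the scatter), so the two chlorophenyl caps are not equivalent, and a chlorophenyl cap as such does not set the number, with compound 1 remaining within the scatter of compound 2. Nothing at hand explains why the 3-chlorophenyl cap stands apart from the other two caps.

Still open, on these data alone, is whether chlorine itself matters, which an unsubstituted phenyl cap, a 3-fluorophenyl cap or a 3-methoxyphenyl cap on the shared core would test. Also open, as far as these compounds go, is whether compound 3 keeps its lower number in other cell lines.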